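The compounds below may be only part of what the source reports. "The series", "measured", "known", "first", "only" and "open" are said of these compounds alone.

Measured compounds:
- compound 1 `Cc1nc2c(cnn2-c2ccccc2)c(=O)n1-c1cccc(Cl)c1`: "not determined" (no result reported)
- compound 2 `Cc1nc2c(cnn2-c2ccccc2)c(=O)n1-c1ccc(OC(F)(F)F)cc1`: > 100000 nM
- compound 3 `Cc1nc2c(cnn2-c2ccccc2)c(=O)n1C1CCCCCC1`: "not determined" (no result reported)

All three share one core and differ only in the group carried on one ring nitrogen. They were examined in an in vitro functional assay on cells for antagonist activity at metabotropic glutamate receptor 5 (Homo sapiens), read by FLIPR and calcium flux; on this read-out higher numbers stand for weaker inhibition and lower numbers for stronger inhibition. For compound 1 the result is "not determined" (no result reported). For the measured compounds named here, for compound 2 the reported value, > 100000 nM, is a limit of the assay rather than a number, and the only evidence on hand is the limit of > 100000 nM in this assay, at which 1 of the 3 values shown sits. For compound 3 the entry is "not determined" (no result reported), so no single number exists for it; neither of the other two entries gives a single number either.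

Compound 4 `Cc1nc2c(cnn2-c2ccccc2)c(=O)n1N1CCCCC1` is not yet measured. It differs from compound 3 by piperidin-1-yl in place of cycloheptyl on an aromatic nitrogen. Going by the values given here, no step between measured compounds is available, so the size of the change cannot be judged from a measured pair. Given that the only numerical information in this series is a limit, compound 4 is expected to give 100000 nM in this assay, within a range of 10000 nM to 1000000 nM, with a substantial chance that only a limit is reported.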

Compound 4, half-maximal inhibitory concentration: 2800 nM
Estimate against measurement, compound 4: 36-fold (1.55 log units) above, outside the stated range (below it).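

No step can be read from compound 3 to compound 4, as compound 3 has no single number for comparison. The compounds shown leave open how compound 4, at 2800 nM, compares with any close neighbour carrying a single number, and whether replacing cycloheptyl with piperidin-1-yl changes inhibition.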